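The compounds below may be only part of what the source reports. "The series", "measured", "known", "first", "only" and "open" are said of these compounds alone.

Measured compounds and their values in a functional assay on JAR cells (Homo sapiens) for inhibition, read by MTT assay, with a stated time of 72 h, tested at 10 uM; on this read-out lower numbers stand for less inhibition and higher numbers for more inhibition at the one concentration tested (going by the name of the read-out):

Compound 1, `CCOC(=O)C1=C(Nc2ccccc2)S/C(=C\c2ccc(OC)cc2)C1=O`: 32.9%
Compound 2, `CCOC(=O)C1=C(Nc2ccccc2)S/C(=C\c2ccc([N+](=O)[O-])c(O)c2)C1=O`: 51.2%
Compound 3, `CCOC(=O)C1=C(Nc2ccccc2)S/C(=C\c2ccc(C(=O)O)cc2)C1=O`: 16.8%

Compound 1 stands second highest of these three numbers. Its nearest neighbour is compound 3, which lies lower by a number 16.1 percentage points lower from compound 1 to compound 3 (beyond the scatter), a step beyond the scatter. Compound 2 lies furthest from it, higher by a margin also beyond the scatter.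

The new compound is compound 4, `CCOC(=O)C1=C(Nc2ccccc2)S/C(=C\c2cccc(C(=O)O)c2)C1=O`. It differs from compound 1 in one place: 3-carboxyphenyl in place of 4-methoxyphenyl on a double-bonded chain carbon bound to a double-bonded ring carbon. The three measured compounds share one core and differ only in the aromatic group attached to the double-bonded chain carbon, so each of them is a single change away from the others.

Going by the values given here, only one measured step bears on this change: the step of a number 16.1 percentage points lower from compound 1 to compound 3 (beyond the scatter), in which carboxy took the place of methoxy on an aromatic carbon and the read-out fell by a modest but real amount. Compound 4 also carries a carboxy group in place of the methoxy group of compound 1, though on a different carbon of the ring, so a fall of similar size is the natural expectation, with wider uncertainty because the ring position is not the same as in compound 3. The expected step is therefore a number 13.9 percentage points lower from compound 1 to compound 4 (beyond the scatter), downward. For compound 4 the estimate in this assay is 19%, with a range from 8% to 33%.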

Compound 4, a percentage reported as inhibition, at one concentration (the size of the read-out at that concentration, not a potency): 50.6%
Compound 4: middle estimate off by 31.6 percentage points, on the low side; measured number above the stated range.
By their numbers in this assay, from the lowest: compound 3; then compound 1; then compounds 4 and 2 (each within the scatter of the next).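

In this assay, the place of the carboxy group on the aromatic ring matters, not just its presence: 3-carboxyphenyl in place of 4-carboxyphenyl gives a number 33.8 percentage points higher from compound 3 to compound 4 (beyond the scatter), a large change from moving one group around the same ring. The earlier step from methoxy to carboxy pointed downward, but it does not hold as a general rule for adding a carboxy group, as the change to 3-carboxyphenyl goes the other way, with a number 17.7 percentage points higher from compound 1 to compound 4 (beyond the scatter). Compound 4 gives 50.6% and compound 2 gives 51.2%, two values within the usual scatter of each other, so a single carboxy group on the ring of compound 4 reaches the level of the differently substituted ring of compound 2.

Nothing available here explains why the two carboxyphenyl isomers lie so far apart. On these data alone, it also remains open whether the higher number belongs to the carboxy group itself or would also appear with another group in the same ring place, such as the methoxy of 3-methoxyphenyl or the amine of 3-aminophenyl on the shared core.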